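The source may report more compounds than this note shows. Statements on the series, on what has been measured and on what is new or still open speak of the compounds shown alone.

Measured in a physicochemical assay for lipophilicity, at pH 7.4; a lower number here means a more polar compound, a higher number a more lipophilic compound:

- compound 1 `COc1ccccc1OCc1cc(C)nc(-c2ccccn2)n1`: 2.5
- compound 2 `CC1(C#N)CN(c2cc(COc3ccc(F)c(F)c3F)nc(-c3ccccn3)n2)C1`: 3.3

Of these two, compound 2 stands higher, and compound 1 lies below it by more than the usual scatter of such measurements. Compound 3 `Fc1ccc(OCc2cc(OCC3(F)COC3)nc(-c3ccccn3)n2)c(F)c1F` has not yet been measured in this assay. It differs from compound 2 in one place: (3-fluorooxetan-3-yl)methoxy in place of 3-cyano-3-methylazetidin-1-yl on an aromatic carbon. On an aromatic carbon, (3-fluorooxetan-3-yl)methoxy takes the place of 3-cyano-3-methylazetidin-1-yl.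

Going by the values given here, no measured pair differs in just one place, so no measured step calibrates this exchange. The two groups match in heavy atoms, in their four-membered non-aromatic ring, and in hydrogen-bond donors and acceptors, although their atoms differ. The expectation therefore starts from compound 2 at 3.3 and allows only a small downward change in this assay, quite possibly none beyond the scatter. The estimated step is a number 0.20 log units lower from compound 2 to compound 3 (within the scatter). For compound 3 the expected value is 3.1, with an estimated range from 2.6 to 3.6.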

Compound 3, distribution coefficient: 4
Beside the measured number, compound 3's estimate is 0.90 log units below it, and the stated range ends below it.
By their numbers in this assay, from the lowest: compound 1; then compound 2; then compound 3.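

In this assay, going by these compounds alone, putting (3-fluorooxetan-3-yl)methoxy in place of 3-cyano-3-methylazetidin-1-yl on this aromatic carbon gives a number 0.70 log units higher from compound 2 to compound 3 (beyond the scatter), the first measured single-place change in this set. The two groups have the same heavy-atom count, the same hydrogen-bond donor and acceptor counts and a four-membered non-aromatic ring each, so at this position those shared counts do not fix the read-out, and the identity of the atoms and how they are arranged can move the number beyond the scatter. Nothing available here bears on why the number moves in this direction or by this amount.

This one pair changes several things at once, since the nitrile, the ring nitrogen and the methyl group leave while the ring oxygen, the ether oxygen and the fluorine enter, and their separate shares cannot be told apart. Also open, as far as these compounds go, is how this position would respond to other groups, such as oxetan-3-ylmethoxy without the fluorine, 3-cyanoazetidin-1-yl without the methyl group, or a morpholin-4-yl ring.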